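The source may report more compounds than this note shows. Statements on the series, on what has been measured and on what is new or still open speak of the compounds shown alone.

Of the compounds shown here, two sharing one core have been tested in a functional assay on HT-29 cells (Homo sapiens) for inhibition, read by sulforhodamine B assay, with a stated time of 48 h; on this read-out lower numbers stand for stronger inhibition of growth and higher numbers for weaker inhibition of growth: compound 1 `CC(C)(C)NCc1c(C(=O)O)nn(-c2ccccc2)c1-c1ccccc1` and compound 2 `CC(C)(C)NCc1c(C(=O)O)nn(-c2ccc(Cl)cc2)c1-c1ccc(Br)cc1`. Compound 1 gives only a limit of the assay, > 716000 nM. Compound 2 also gives only a limit, > 542000 nM. Compound 2 therefore has no numerical value in this assay and cannot be ranked against compound 1.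

The next compound, compound 3 `CC(C)(C)NCc1c(C(=O)O)nn(-c2ccc(Cl)cc2)c1-c1ccccc1`, has hydrogen in place of bromo on an aromatic carbon of compound 2, on a six-membered aromatic ring of carbon only, para to a large group (hydrogen in place of bromo on an aromatic carbon). The same difference reads 4-bromophenyl to phenyl. Among the measured compounds shown here, no measured pair isolates this change. The closest guide is compound 1, which carries no bromo and still reaches only the limit > 716000 nM. No change beyond the usual scatter is therefore expected in this assay, and a further limit is the likeliest report. The estimated step that the limit leaves unreadable from compound 2 to compound 3 is expected to stay within that scatter. For compound 3 the expected value is 650000 nM, within an estimated range of 300000 nM to 1000000 nM.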

Compound 3, concentration for 50% growth inhibition: > 652000 nM
Compound 3 was reported as a limit; the forecaster's own chance of this, stated with the estimate: 85%; middle value at least 1.0-fold (0.00 log units) from the limit.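

In this assay compound 3 gives only a limit, > 652000 nM. Compound 1, compound 2 and compound 3 all stand at limits, so neither the step from compound 2 to compound 3 nor the step from compound 1 to compound 3 can be read. The compounds shown leave open whether bromo or chloro changes growth inhibition at all in this assay.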